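Fluoro in place of chloro on an aromatic carbon

The source may report more compounds than this note shows. Statements on the series, on what has been measured and on what is new or still open speak of the compounds shown alone.

Compound 1, `O=C(Nc1ccc(Oc2ccnc3[nH]ccc23)cc1)c1nccc(-c2cccc(Cl)c2)n1`: 4120 nM in a functional assay on A549 cells (Homo sapiens) for cytotoxicity, read by MTT assay, with a stated time of 72 h; on this read-out higher numbers stand for weaker inhibition and lower numbers for stronger inhibition
Compound 2, `COc1ccc(-c2ccnc(C(=O)Nc3ccc(Oc4ccnc5[nH]ccc45)cc3)n2)cc1`: 13300 nM
Compound 3, `O=C(Nc1ccc(Oc2ccnc3[nH]ccc23)cc1)c1nccc(-c2ccc(Cl)cc2)n1`: 22400 nM

Compound 3 gives the highest number of the three. The steps of a 5.4-fold higher number from compound 1 to compound 3 (0.74 log units; beyond the scatter) and a 1.7-fold higher number from compound 2 to compound 3 (0.23 log units; within the scatter) place it beyond the scatter from compound 1 but within it of compound 2. Compound 4, `O=C(Nc1ccc(Oc2ccnc3[nH]ccc23)cc1)c1nccc(-c2ccc(F)cc2)n1`, differs from compound 3 by fluoro in place of chloro on an aromatic carbon. Among the compounds with values here, no measured step exchanges one halogen for another. Within the data shown here, the one step at the same place, a 1.7-fold higher number from compound 2 to compound 3 (0.23 log units; within the scatter), lies within the scatter, while a 3.2-fold higher number from compound 1 to compound 2 (0.51 log units; beyond the scatter) and a 5.4-fold higher number from compound 1 to compound 3 (0.74 log units; beyond the scatter) both involve the 3-chlorophenyl group of compound 1 and so bear only loosely on this change. The expected step in this assay is therefore small, a 1.2-fold lower number from compound 3 to compound 4 (0.09 log units; within the scatter), with no clear direction. Compound 4 is estimated at about 18000 nM, within a range from 7000 nM to 45000 nM.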

Compound 4, half-maximal inhibitory concentration: "not active" (no number reported)
Compound 4: no number reported, and the estimate cannot be compared.
By their numbers in this assay, from the lowest: compound 1; then compounds 2 and 3 (each within the scatter of the next).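

In this assay, within the data shown here, compound 4 is reported only as "not active", without a number, so no step from compound 3 to compound 4 can be read. No evidence bears on this result. The compounds shown leave open how 4-fluorophenyl compares with 4-chlorophenyl here.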